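Moving an acid one carbon outward on a second chain

The source may hold more compounds than are shown below. What is called first, only, known or untested is meant among the compounds shown, and "the series" means these compounds.

Compound 1, `Cc1c(Cl)cccc1CCCCOc1ccc(C#Cc2cccc3c(CCCC(=O)O)c(C)n(CC(=O)O)c23)cc1`, carries two acid-bearing chains on its shared core, a longer one on a saturated chain carbon bound to an aromatic carbon and a short one on a saturated chain carbon bound to an aromatic nitrogen. In a functional assay on HEK293 cells for antagonist activity at cysteinyl leukotriene receptor 2 (Homo sapiens), read by fluorescence and calcium flux, with stated times of 30 min and 1 h (a lower number here means a stronger inhibitor, a higher number a weaker inhibitor), compound 1 gives 0.88 nM. Compound 2, `Cc1c(Cl)cccc1CCCCOc1ccc(C#Cc2cccc3c(CCCC(=O)O)c(C)n(CCC(=O)O)c23)cc1`, differs from it in one place: carboxymethyl in place of carboxy on a saturated chain carbon bound to an aromatic nitrogen. In this assay compound 2 gives 22 nM, and the step of a 25-fold higher number from compound 1 to compound 2 (1.40 log units; beyond the scatter) shows what that single change cost.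

Compound 3, `Cc1c(Cl)cccc1CCCCOc1ccc(C#Cc2cccc3c(CC(=O)O)c(C)n(CCCCC(=O)O)c23)cc1`, is built on the same framework, but the difference between its core and that of compound 1 is not broken down here. In this assay compound 3 gives 248 nM, the highest number among the three measured compounds.

Compound 4, `Cc1c(Cl)cccc1CCCCOc1ccc(C#Cc2cccc3c(CCC(=O)O)c(C)n(CCCCC(=O)O)c23)cc1`, has not yet been measured. It differs from compound 3 in one place: carboxymethyl in place of carboxy on a saturated chain carbon bound to an aromatic carbon. Among the measured compounds shown here, this is the same kind of change as the one from compound 1 to compound 2, yet not the same change, since there the place was on a saturated chain carbon bound to an aromatic nitrogen and here it is on a saturated chain carbon bound to an aromatic carbon. For the measured compounds named here, the only measured precedent, a 25-fold higher number from compound 1 to compound 2 (1.40 log units; beyond the scatter), points to a loss. That precedent was made at a different place, and no measurement shows whether its size carries over. For compound 4 a smaller loss is expected, estimated as a 1.4-fold higher number from compound 3 to compound 4 (0.15 log units; within the scatter). Compound 4 is therefore estimated at 350 nM, within 70 nM to 2000 nM.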

Compound 4, half-maximal inhibitory concentration: 60 nM
Beside the measured number, compound 4's estimate is 5.8-fold (0.77 log units) above it; the measured number lies below the stated range.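

In this assay, carboxymethyl in place of carboxy on a saturated chain carbon bound to an aromatic carbon gives a 4.1-fold lower number from compound 3 to compound 4 (0.62 log units; beyond the scatter), so here the added carbon brings a gain in potency, not a loss. Set beside the earlier step, the change does not carry from one core to the other in this series, either in direction or in size: the same change on two cores in this assay, a 25-fold higher number (1.40 log units; beyond the scatter) from compound 1 to compound 2 and a 4.1-fold lower number (0.62 log units; beyond the scatter) from compound 3 to compound 4, 100-fold (2.01 log units) apart, beyond the scatter of two such steps

This does not show what sets the two steps apart: they lie at different places, one on a saturated chain carbon bound to an aromatic nitrogen and the other on a saturated chain carbon bound to an aromatic carbon, and the second acid-bearing chain also differs between the two pairs, so a single pair of steps cannot separate these factors or give a rule for any further core.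

The compounds shown leave open whether a longer chain ending in a carboxylic acid on the aromatic carbon would extend the gain seen with compound 4 or reverse it. They also leave open how either chain would behave if a tetrazole or a primary amide stood in place of its carboxylic acid.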